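Swapping isopentyl for 2-cyclopentylethyl on the shared core

The source may hold more compounds than are shown below. What is called first, only, known or untested is meant among the compounds shown, and "the series" means these compounds.

Measured in a functional assay on ACHN cells (Homo sapiens) for antiproliferative activity, read by sulforhodamine B assay; on this read-out higher numbers stand for weaker inhibition of growth and lower numbers for stronger inhibition of growth:
- compound 1 `O=C(/C=C/c1ccc(O)cc1)c1c(O)cccc1OCCC1CCCCC1`: > 30000 nM (a limit of the assay)
- compound 2 `O=C(/C=C/c1ccc(O)cc1)c1c(O)cccc1OCC1CCCC1`: 3510 nM
- compound 3 `CC(C)CCOc1cccc(O)c1C(=O)/C=C/c1ccc(O)cc1`: 11300 nM

Of the two true numbers, the higher belongs to compound 3 at 11300 nM. Compound 4 `O=C(/C=C/c1ccc(O)cc1)c1c(O)cccc1OCCC1CCCC1` has not been measured. It differs from compound 3 as follows: cyclopentyl in place of isopropyl on a saturated chain carbon, two bonds along the chain from an oxygen on an aromatic ring. Within the data shown here, two measured steps bear on this and point in opposite directions. The open chain did worse than a cyclopentyl-bearing chain in a 3.2-fold higher number from compound 2 to compound 3 (0.51 log units; beyond the scatter), yet it did better than a cyclohexyl-bearing chain in an at least 2.6-fold lower number from compound 1 to compound 3 (0.42 log units; beyond the scatter). No change beyond the scatter is therefore expected in this assay. The expected step is a 1.0-fold lower number from compound 3 to compound 4 (0.01 log units; within the scatter). Compound 4 is estimated at 11000 nM, with an expected range of 4500 nM to 28000 nM.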

Compound 4, concentration for 50% growth inhibition: 3400 nM
Compound 4: middle estimate off by 3.2-fold (0.51 log units), on the high side; the whole stated range lies above it.
By their numbers in this assay, from the lowest: compounds 4 and 2 (each within the scatter of the next); then compound 3. At a limit, above all of these: compound 1.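

In this assay, a cyclopentyl ring at the end of this chain beats the open isopentyl end, with a 3.3-fold lower number from compound 3 to compound 4 (0.52 log units; beyond the scatter). Moving that ring further from the oxygen shows no change beyond the scatter, with a 1.0-fold lower number from compound 2 to compound 4 (0.01 log units; within the scatter). Ring size matters as well, with an at least 8.8-fold lower number from compound 1 to compound 4 (0.94 log units; beyond the scatter), and the value for compound 1 is a limit of the assay, not a true number: the limit of > 30000 nM in this assay, at which 1 of the 4 values shown sits.

On these data alone, whether a still longer chain before the cyclopentyl ring would hold this level of growth inhibition stays open. So does the effect of a cyclobutyl ring or of an amine at the chain end.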